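The compounds below may be only part of what the source reports. "The series", "measured", "known", "first", "only" and "open" are said of these compounds alone.

Measured in a functional assay on MDA-N cells (Homo sapiens); on this read-out higher numbers stand for weaker inhibition of growth and lower numbers for stronger inhibition of growth:
- Compound 1 `Cc1cc(C)c2c(O)cc(-c3ccc(Cl)cc3)nc2n1`: 3630 nM
- Compound 2 `Oc1cc(-c2ccc(Cl)cc2)nc2ncccc12`: 8320 nM

Compound 1 has the lower of these two numbers, so it inhibits growth more strongly than compound 2, and the gap between them lies beyond the usual scatter of repeated measurements. The next compound to be tested, compound 3 `COc1ccc(-c2cc(O)c3c(C)cc(C)nc3n2)cc1`, keeps the core of compound 1 but has methoxy in place of chloro on an aromatic carbon, para to a large group (methoxy in place of chloro on an aromatic carbon). For the measured compounds named here, no measured pair shows this swap, so the data cannot give its size or direction. Going by the values given here, the only anchor is compound 1 at 3630 nM, and no shift beyond the scatter in this assay is expected. The estimated step is a 1.1-fold higher number from compound 1 to compound 3 (0.04 log units; within the scatter). For compound 3 the expected value is 4000 nM, with an estimated range from 1500 nM to 12000 nM.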

Compound 3, concentration for 50% growth inhibition: 33100 nM
Beside the measured number, compound 3's estimate is 8.3-fold (0.92 log units) below it; the whole stated range lies below it.
By their numbers in this assay, from the lowest: compound 1; then compound 2; then compound 3.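

In this assay, placing methoxy in place of chloro on this aromatic carbon, para to a large group, gives a 9.1-fold higher number from compound 1 to compound 3 (0.96 log units; beyond the scatter) and so a clear loss of growth inhibition. Compounds 1 and 2 both carry chloro here and could say nothing about this position, whereas compound 3 shows that growth inhibition depends strongly on the group at this carbon. Nothing available explains why this swap weakens growth inhibition so much.

Going by these compounds, this reading rests on a single pair of compounds, so it remains open whether the loss is particular to methoxy or follows from replacing chloro with other groups. Fluoro, bromo, methyl or an amine on the same carbon would show whether chloro itself matters or whether methoxy is the exception.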